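Swapping the morpholine amide arm for a methylbenzyl group

A few compounds are considered here, and "the series" means these few. Any claim that something is new, unique, unknown or untested is made for them only; others in the source may bear on it.

Compound 1 `COc1cc(-c2nc3cc(/C=C4\SC(=O)N(CC(=O)N5CCOCC5)C4=O)ccc3[nH]2)cc(OC)c1OC` gives the only number shown in an ADME assay on HEK-293T cells (Homo sapiens) for inhibition, read by MTT assay, with a stated time of 48 h (a lower number here means a stronger inhibitor, a higher number a weaker inhibitor), namely 18800 nM. Compound 2 `COc1ccc(-c2nc3cc(/C=C4\SC(=O)N(CC(=O)N5CCOCC5)C4=O)ccc3[nH]2)cc1OC` reaches only a limit in this assay, > 50000 nM, which is the limit of > 50000 nM in this assay, at which 1 of the 2 values shown sits. Going by the values given here, the single measured step, an at least 2.6-fold higher number from compound 1 to compound 2 (0.42 log units; beyond the scatter), concerns hydrogen in place of methoxy on an aromatic carbon. Compound 3 `COc1cc(-c2nc3cc(/C=C4\SC(=O)N(Cc5cccc(C)c5)C4=O)ccc3[nH]2)cc(OC)c1OC` differs from compound 1 at another position: 3-methylphenyl in place of (morpholin-4-yl)carbonyl on a saturated chain carbon bound to an amide-type nitrogen in a ring. Among the compounds with values here, no measured step touches that position, so the data give no guide to direction or size in this assay. Compound 3 is therefore expected near 15000 nM, between 4000 nM and 50000 nM. That estimate means a step of a 1.3-fold lower number from compound 1 to compound 3 (0.10 log units; within the scatter), expected to stay within the scatter.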

Compound 3, half-maximal inhibitory concentration: 18900 nM
For compound 3 the middle estimate is 1.3-fold (0.10 log units) below the measured one; measured number inside the range.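

At the saturated chain carbon bound to an amide-type nitrogen in a ring, 3-methylphenyl in place of (morpholin-4-yl)carbonyl gives a 1.0-fold higher number from compound 1 to compound 3 (0.00 log units; within the scatter) in this assay. This position therefore accepts an arm of carbon only, with 0 hydrogen-bond acceptors, in place of one with 2, and the number stays within the scatter. Nothing at hand gives a reason for this result.

From the compounds shown here alone, it remains open how an amine, a carboxylic acid or a longer chain would read at this position. Going by these compounds, it also remains open whether 3-methylphenyl would behave the same way on the core of compound 2.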